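A few compounds are considered here, and "the series" means these few. Any claim that something is new, unique, unknown or untested is made for them only; others in the source may bear on it.

Working notes on the series. For the measured compounds named here, in a functional assay on PC-3 cells (Homo sapiens) for antiproliferative activity, read by MTT assay, with a stated time of 72 h (a higher number here means a weaker inhibitor, a lower number a stronger inhibitor), compound 1 `C/C(=N\NC(=O)c1cccc(S(=O)(=O)N2CCOCC2)c1)c1ccccc1O` gives 2810 nM, the lower of the two numbers so far. Compound 2 `C/C(=N\NC(=O)c1cccc(S(=O)(=O)N2CCOCC2)c1)c1ccc(O)cc1` gives 36200 nM in this assay and carries 4-hydroxyphenyl in place of 2-hydroxyphenyl. Going by the values given here, that exchange is the only measured step, a 13-fold higher number from compound 1 to compound 2 (1.11 log units; beyond the scatter), and it is large and beyond the scatter.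

Compound 3 `C/C(=N\NC(=O)c1cccc(S(=O)(=O)N2CCOCC2)c1)c1cc(F)ccc1O` differs from compound 1 by fluoro in place of hydrogen on an aromatic carbon, which reads as 2-hydroxyphenyl to 5-fluoro-2-hydroxyphenyl, with the fluoro para to a hydroxy group. The measured step bears on this only loosely. It concerns where the hydroxy group sits, and compound 3 keeps the hydroxy group of compound 1. Among the compounds with values here, no measured step replaces hydrogen with fluoro, so the data give no direction for this change. A shift of the size seen from 2-hydroxyphenyl to 4-hydroxyphenyl is not expected, and a small step, probably within the scatter, is the working expectation.

The estimate therefore means a 1.1-fold lower number from compound 1 to compound 3 (0.05 log units; within the scatter) as the expected step. Compound 3 is expected at 2500 nM in this assay, with an estimated range from 900 nM to 7000 nM as the outcome.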

Compound 3, half-maximal inhibitory concentration: 4410 nM
Estimate against measurement, compound 3: 1.8-fold (0.25 log units) below, within the range that was stated.
By their numbers in this assay, from the lowest: compounds 1 and 3 (each within the scatter of the next); then compound 2.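

Working notes, continued. In this assay, for the compounds shown here, the aromatic carbon para to a hydroxy group accepts fluoro in place of hydrogen with little consequence: a 1.6-fold higher number from compound 1 to compound 3 (0.20 log units; within the scatter) is the first reading of any exchange at this position, and it shows that a single fluorine here leaves compound 3 within the scatter of compound 1. The separation from the 4-hydroxyphenyl series also persists with the fluoro present, since an 8.2-fold lower number from compound 2 to compound 3 (0.91 log units; beyond the scatter) remains a step beyond the scatter, so the 5-fluoro-2-hydroxyphenyl group of compound 3 stays on the same side of that gap as the 2-hydroxyphenyl group of compound 1. No supporting information bears on either step, so neither can be explained from what is at hand.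

Fluoro is the only group shown at this carbon, so it remains open whether chloro, methoxy or an amine there would also stay within the scatter of compound 1. Going by these compounds alone, it is equally open whether fluoro on the 4-hydroxyphenyl ring of compound 2 would give a step of similar size, as this series holds only one fluorinated compound.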